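Adding a methyl to compound 3

This account rests on a few compounds, and the source may have more. Where it says the series, first, only, none or still open, it means among the compounds named here.

In an ADME assay on the whole organism (Mus musculus, strain CD1) for pharmacokinetics, read by LC-MS, with a stated time of 24 h, at a dose of 1 mg/kg by the intravenous route (a lower number here means slower removal, a higher number faster removal of the compound), compound 3 (`O=C(O)Cc1nn(Cc2cn3cc(OCC4CC4)c(Cl)cc3n2)c2ccccc2c1=O`) gives 11.7 mL/min/kg. Compound 2 (`O=C(O)Cn1nc(Cc2nc3cc(F)c(OCC4CC4)cc3[nH]2)c2ccccc2c1=O`) gives 21.7 mL/min/kg, within the scatter of compound 3. Compound 1 (`O=C(O)Cn1nc(Cc2nc3cc(Cl)c(OCC(F)F)cc3[nH]2)c2ccccc2c1=O`) gives 51.7 mL/min/kg, a higher number than compound 3 and beyond the scatter.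

Compound 4 (`C[C@H](C(=O)O)c1nn(Cc2cn3cc(OCC4CC4)c(Cl)cc3n2)c2ccccc2c1=O`) differs from compound 3 by methyl in place of hydrogen on a saturated chain carbon bound to an aromatic carbon and a carbonyl carbon. Among the compounds with values here, no measured pair differs in one place, so the data give no direct reading of this change. In this assay, no step beyond the scatter is expected. The estimated change is a 1.1-fold lower number from compound 3 to compound 4 (0.03 log units; within the scatter). The expected value for compound 4 is 11 mL/min/kg, with a range of 5 mL/min/kg to 24 mL/min/kg.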

Compound 4, clearance: 7.83 mL/min/kg
Compound 4: the middle estimate sits 1.4-fold (0.15 log units) above what was measured, and the stated range covers the measured number.
By their numbers in this assay, from the lowest: compounds 4, 3 and 2 (each within the scatter of the next, the first and the last beyond it); then compound 1.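

Within the data shown here, the step of a 1.5-fold lower number from compound 3 to compound 4 (0.17 log units; within the scatter) in this assay is the first single-place reading. Carboxymethyl to 1-carboxyethyl, on a saturated chain carbon bound to an aromatic carbon and a carbonyl carbon, therefore leaves clearance within the scatter. Nothing shown accounts for the size of this step.

From the compounds shown here alone, whether an ethyl or a hydroxyl on this carbon, or the opposite configuration of the methyl, would also stay within the scatter of compound 3 remains open. So does whether the same methyl would give a similar step on the core of compound 2.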